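Cyano for Chloro on the Aryl Ring of Compound 3

The compounds below may be only part of what the source reports. "The series", "measured", "known", "first", "only" and "open" are said of these compounds alone.

Three compounds have been measured in a functional assay on MCF7 cells (Homo sapiens) for inhibition; on this read-out lower numbers stand for stronger inhibition and higher numbers for weaker inhibition:

Compound 1, `CC/C(=C(/c1ccc(/C=C/C(=O)O)cc1)c1cc2ccccc2[nH]1)c1cccc(C)c1`, gives 140 nM.
Compound 2, `CC/C(=C(/c1ccc(/C=C/C(=O)O)cc1)c1cc2ccccc2[nH]1)c1cccc(C(F)(F)F)c1`, gives 325 nM.
Compound 3, `CC/C(=C(/c1ccc(/C=C/C(=O)O)cc1)c1cc2ccccc2[nH]1)c1ccc(Cl)cc1Cl`, gives 11 nM.

Among these, compound 3 stands lowest in this assay, and both steps toward it are beyond the scatter: a 13-fold lower number from compound 1 to compound 3 (1.10 log units; beyond the scatter), and a 30-fold lower number from compound 2 to compound 3 (1.47 log units; beyond the scatter). The remaining step is smaller: a 2.3-fold higher number from compound 1 to compound 2 (0.37 log units; beyond the scatter).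

Compound 4, `CC/C(=C(/c1ccc(/C=C/C(=O)O)cc1)c1cc2ccccc2[nH]1)c1ccc(C#N)cc1Cl`, differs from compound 3 in one place: cyano in place of chloro on an aromatic carbon. No measured pair swaps a cyano for a chloro, so the bearing of the shown steps is indirect. They show that exchanging the whole aryl ring moved the number a great deal, while a single substituent swap within the same ring type, as from compound 1 to compound 2, moved it only modestly. The change here is of the second kind, a single substituent on a ring that otherwise keeps its 2-chloro group, so a modest step is expected, more likely toward a higher number than a lower one.

Compound 4 is therefore expected to give 25 nM, within a range of 8 nM to 80 nM, which corresponds to an expected step of a 2.3-fold higher number from compound 3 to compound 4 (0.36 log units; beyond the scatter).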

Compound 4, half-maximal inhibitory concentration: 49 nM
Compound 4: middle estimate off by 2.0-fold (0.29 log units), on the low side, and the stated range covers the measured number.
By their numbers in this assay, from the lowest: compound 3; then compound 4; then compound 1; then compound 2.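

The swap from chloro to cyano, on the aromatic carbon para to a large group, gives in this assay a 4.5-fold higher number from compound 3 to compound 4 (0.65 log units; beyond the scatter) and so shows directly that this one position alone can move the number beyond the scatter, even with the 2-chloro group kept. The change does not cancel the advantage of the ring, since the 2-chloro-4-cyanophenyl compound still stands ahead of the two compounds with a substituent at the third ring position, with a 6.6-fold lower number from compound 2 to compound 4 (0.82 log units; beyond the scatter) and with a 2.9-fold lower number from compound 1 to compound 4 (0.46 log units; beyond the scatter) as the two steps; across these four compounds, both rings with the 2-chloro group give lower numbers than the two without it, and none goes against this. Nothing available bears on what lies behind the step from chloro to cyano.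

The compounds shown leave open how much of the advantage belongs to the 2-chloro group itself, since neither ring carrying it has a plain hydrogen at the para position. They also leave open whether a fluoro, a methoxy or an amine at this same place would stay nearer to compound 3 or to compound 4.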